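Adding an imidazolyl group to compound 3

A few compounds are considered here, and "the series" means these few. Any claim that something is new, unique, unknown or untested is made for them only; others in the source may bear on it.

For the measured compounds named here, in a functional assay for inhibition, with Rattus norvegicus as the target (a lower number here means a stronger inhibitor, a higher number a weaker inhibitor), compound 3 `CC(/N=c1\c(O)c(O)\c1=N/c1ccccc1)C(C)(C)C` gives 5400 nM, the only actual number in this small set. Compound 1 `CC(/N=c1\c(O)c(O)\c1=N/c1cccnc1O)C(C)(C)C` reaches only a limit, > 30000 nM. Compound 2 `COc1cc(/N=c2\c(O)c(O)\c2=N/C(C)C(C)(C)C)c2ncccc2c1` also reaches only a limit, > 30000 nM. Compound 4 `CC(/N=c1\c(O)c(O)\c1=N/c1ccc(-n2ccnc2)cc1)C(C)(C)C` differs from compound 3 by 1H-imidazol-1-yl in place of hydrogen on an aromatic carbon. Going by the values given here, the single measured step, an at least 5.5-fold lower number from compound 1 to compound 3 (0.74 log units; beyond the scatter), lies beyond the scatter, but it swaps the whole group on a double-bonded nitrogen and does not test this addition. No direction can therefore be expected with confidence, and a result at the limit of > 30000 nM in this assay, at which 2 of the 3 values shown sit, remains possible. The expected change is small, a 1.1-fold lower number from compound 3 to compound 4 (0.03 log units; within the scatter). Compound 4 is estimated at 5000 nM, with an expected range from 1000 nM to 25000 nM.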

Compound 4, half-maximal inhibitory concentration: > 30000 nM
Compound 4: a limit, no number (the forecaster's own chance of this, stated with the estimate: 25%); middle value at least 6.0-fold (0.77 log units) away from the limit.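

In this assay, placing 1H-imidazol-1-yl on an aromatic carbon, para to a large group, brings an at least 5.5-fold higher number from compound 3 to compound 4 (0.74 log units; beyond the scatter). Unlike the earlier step, which swapped the whole group on the double-bonded nitrogen, this one isolates a single addition to the phenyl group and shows that this addition weakens inhibition. Its full size cannot be read, as the value of compound 4 is a limit and not a number: the limit of > 30000 nM in this assay, at which 3 of the 4 values shown sit.

The compounds shown leave open whether a methyl group, a methoxy group or an amine on the same aromatic carbon would keep the inhibition of compound 3.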